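Replacing the hydroxy group on the amide nitrogen

This account rests on a few compounds, and the source may have more. Where it says the series, first, only, none or still open, it means among the compounds named here.

compound 1 `O=C(NO)c1ccc(CNc2nccc(-c3cccnc3)n2)cc1`: 42 nM
compound 2 `Nc1ccccc1NC(=O)c1ccc(CSC2=N[C@@H](Cc3ccccc3)CS2)cc1`: > 20000 nM

Within the data shown here, in an assay on isolated protein for inhibition of protein deacetylase HDAC6 (Homo sapiens), read by fluorescence, with stated times of 3 h and 60 min (on this read-out lower numbers stand for stronger inhibition and higher numbers for weaker inhibition), compound 1 gives 42 nM, the only proper number in the set. For compound 2 the read-out is a limit, not a number: > 20000 nM. Compound 3 `Nc1cc2ccccc2cc1NC(=O)c1ccc(CNc2nccc(-c3cccnc3)n2)cc1` is not yet measured; it differs from compound 1 by a group of 11 heavy atoms (10 carbon, 1 nitrogen; 2 six-membered aromatic rings of carbon only) in place of one oxygen atom, on an amide-type nitrogen. Among the measured compounds shown here, no measured pair covers this step, and the only other amide-type compound, compound 2, sits at the limit of > 20000 nM in this assay, at which 1 of the 2 values shown sits. A large step toward weaker inhibition is expected from compound 1 to compound 3, a 190-fold higher number from compound 1 to compound 3 (2.28 log units; beyond the scatter). Compound 3 is estimated at 8000 nM, range 1500 nM to 30000 nM, with a fair chance that only a limit is reported.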

Compound 3, half-maximal inhibitory concentration: > 20000 nM
Compound 3 was reported as a limit; the forecaster's own chance of this, stated with the estimate: 40%; middle value at least 2.5-fold (0.39 log units) away from the limit.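

In this assay, among these compounds, the exchange of the hydroxy on the amide-type nitrogen for the group of 11 heavy atoms, with the rest of the core of compound 1 unchanged, gives an at least 470-fold higher number from compound 1 to compound 3 (2.67 log units; beyond the scatter) and so provides the first single-place step. The reading for compound 3 is a limit, not a number, so the step has no upper bound, and the set now reads: the limit of > 20000 nM in this assay, at which 2 of the 3 values shown sit.

The compounds shown leave open how much of the loss follows the departure of the hydroxy and how much the entry of the two aromatic rings. A methoxy or an amino group on that nitrogen would bear on this.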